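A few compounds are considered here, and "the series" means these few. Any claim that something is new, unique, unknown or untested is made for them only; others in the source may bear on it.

Of the compounds shown here, two built on the same core have been measured in an assay for inhibition of Dihydrofolate reductase (Bos taurus), at pH 6.25; on this read-out lower numbers stand for lower potency and higher numbers for higher potency (the scale is a negative logarithm). Compound 1 `CC1(C)N=C(N)N=C(N)N1c1ccccc1F` carries fluoro, and in this assay compound 1 gives 4.86. Compound 2 `CC1(C)N=C(N)N=C(N)N1c1ccccc1Cl` carries chloro in its place, and in this assay compound 2 gives 4.86. Within the data shown here, the single measured step, no change at the digits printed from compound 1 to compound 2 (within the scatter), shows that chloro in place of fluoro on an aromatic carbon leaves the read-out where it was. Compound 2 therefore stands level with compound 1 at the digits shown, within the scatter of the method.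

Compound 3 `CC1(C)N=C(N)N=C(N)N1c1ccccc1I` has not yet been measured. It differs from compound 2 as follows: iodo in place of chloro on an aromatic carbon. Among the measured compounds shown here, the only measured step that bears on this change is the one in which chloro replaced fluoro, from compound 1 to compound 2, and that step produced no change beyond the scatter. On that basis the expected step is a number 0.04 log units higher from compound 2 to compound 3 (within the scatter), nothing beyond the scatter. Compound 3 is accordingly estimated at 4.9 in this assay, with a range from 4.5 to 5.3.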

Compound 3, logarithm of the reciprocal of the active concentration, log(1/C): 3.43
For compound 3 the middle estimate is 1.47 log units above the measured one; measured number outside the range, below it.
By their numbers in this assay, from the lowest: compound 3; then compounds 1 and 2 (each within the scatter of the next).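

The halogen on this aromatic carbon, ortho to a large group, cannot be exchanged freely in this assay. The read-out shows no change at the digits printed from compound 1 to compound 2 (within the scatter), but iodo in place of chloro gives a number 1.43 log units lower from compound 2 to compound 3 (beyond the scatter), and iodo in place of fluoro gives a number 1.43 log units lower from compound 1 to compound 3 (beyond the scatter), so the agreement between fluoro and chloro does not extend to every halogen at this position. Compound 3 is therefore the least potent of the three, and nothing available here accounts for the loss.

The compounds shown leave open whether the loss is specific to iodo or would also appear with other groups on this carbon, such as bromo, methyl, methoxy or an amine, which could stay level with fluoro and chloro or fall towards iodo. They also leave open whether iodo would give a comparable loss on another carbon of the same aromatic ring, since all three halogens shown occupy the same place on the shared core.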